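From Compound 3 to Compound 4 in Mice

A few compounds are considered here, and "the series" means these few. Any claim that something is new, unique, unknown or untested is made for them only; others in the source may bear on it.

This account follows four compounds that share one core. Compound 1 `COc1ccc(C2CC(Nc3nc4ccccc4s3)=NN2C(C)=O)cc1O` and compound 2 `CC(=O)N1N=C(Nc2nc3ccc(Cl)cc3s2)CC1c1ccccc1` were tested in a functional assay on the whole organism (strain albino) with Mus musculus as the target, with a stated time of 0.5 h (on this read-out higher numbers stand for an effect only at larger amounts of compound and lower numbers for an effect already at smaller amounts), but compound 1 gives "not determined" (no result reported) and compound 2 gives "not determined" (no result reported), so neither contributes a number. Compound 3 `CC(=O)N1N=C(Nc2nc3ccc(Cl)cc3s2)CC1c1ccc(O)cc1` is therefore the only compound with a reported value: in this assay compound 3 gives 107 umol/kg, and it stands alone on the numbers shown, with no second number to compare it against.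

Compound 4 `COc1ccc(C2CC(Nc3nc4ccc(Cl)cc4s3)=NN2C(C)=O)cc1O` differs from compound 3 in one place: 3-hydroxy-4-methoxyphenyl in place of 4-hydroxyphenyl on a saturated ring carbon. Within the data shown here, with no measured step between related compounds available, there is nothing in these data to show which direction such a change takes in this assay, and the expectation is that the step from compound 3 to compound 4 stays within the usual scatter, though a modest shift in either direction would not be surprising; the step expected is a 1.1-fold higher number from compound 3 to compound 4 (0.05 log units; within the scatter).

In this assay compound 4 is estimated to give 120 umol/kg, with a range from 50 umol/kg to 300 umol/kg.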

Compound 4, dose for half-maximal effect: 132 umol/kg
For compound 4 the middle estimate is 1.1-fold (0.04 log units) below the measured one; low and high end bracket the measured number.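

In this assay, among these compounds, the first measured step is a 1.2-fold higher number from compound 3 to compound 4 (0.09 log units; within the scatter), so at this saturated ring carbon 3-hydroxy-4-methoxyphenyl and 4-hydroxyphenyl give values within the scatter of each other, even though the entering group has more heavy atoms and an extra hydrogen-bond acceptor. Compound 1 and compound 2 carry no number, so any steps to them cannot be read. Nothing shown here offers an explanation for this result.

Still open, on these data alone, is how this position responds to a group of a different kind, such as an amine or a carboxylic acid on the phenyl ring, or a longer chain in place of that ring. Also open, as far as these compounds go, is what the chlorine on the shared core contributes, as compound 1, which lacks it, has no reported result.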